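A Phenyl Substituent Replaces a Benzyl Group on a Shared Core

This account rests on a few compounds, and the source may have more. Where it says the series, first, only, none or still open, it means among the compounds named here.

Of the compounds shown here, three have been measured in a functional assay on MCF7 cells (Homo sapiens) for inhibition, read by CCK-8 assay, with a stated time of 48 h (a higher number here means a weaker inhibitor of growth, a lower number a stronger inhibitor of growth), and one awaits testing. Compound 1 `Cc1ccccc1Nc1nc(NC2CC2)ncc1Cl` carries a cyclopropyl group on a nitrogen of the shared core. In this assay compound 1 gives > 100000 nM, which is a limit of the assay and not a number. Compound 2 `Cc1ccccc1Nc1nc(NC2CCCCC2)ncc1Cl` carries a cyclohexyl in place of the cyclopropyl. In this assay compound 2 gives > 100000 nM, again a limit. The step that the two limits leave unreadable from compound 1 to compound 2 therefore has no readable size. For the measured compounds named here, compound 3 `CN1CCN(c2ccc(Nc3ncc(Cl)c(NCc4ccc(F)cc4)n3)nc2)CC1` is the only compound with a numerical value: in this assay compound 3 gives 19300 nM. The two other values sit at the limit of > 100000 nM in this assay, at which 2 of the 3 values shown sit.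

Compound 4 `CN1CCN(c2ccc(Nc3ncc(Cl)c(Nc4ccc(C(C)(C)C)cc4)n3)nc2)CC1` differs from compound 3 in one place: 4-(tert-butyl)phenyl in place of 4-fluorobenzyl on a nitrogen on an aromatic ring. Going by the values given here, no measured step involves this exchange, and the single measured step lies between two limits, so it offers nothing to lean on. The expectation for compound 4 rests on compound 3 alone and carries a wide range. Compound 4 is expected to give about 12000 nM, between 2000 nM and 70000 nM. The step of a 1.6-fold lower number from compound 3 to compound 4 (0.21 log units; within the scatter) is estimated to stay within the usual scatter.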

Compound 4, concentration for 50% growth inhibition: 12600 nM
The estimate for compound 4 lay 1.1-fold (0.02 log units) below the measured number; the range from low to high includes it.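

In this assay, for the compounds shown here, the exchange of 4-fluorobenzyl for 4-(tert-butyl)phenyl on a nitrogen on an aromatic ring gives the first readable step in this set, a 1.5-fold lower number from compound 3 to compound 4 (0.19 log units; within the scatter), whereas the earlier step between compound 1 and compound 2 cannot be read. The group that leaves and the group that enters each have one six-membered aromatic ring of carbon only, and this one exchange leaves the two values within the usual scatter of each other. This is a single pair of compounds, so it shows only that these two groups read alike at this place, and not every value shown gives a number: the limit of > 100000 nM in this assay, at which 2 of the 4 values shown sit.

On these data alone, it remains open whether a group of another kind at this place, such as an amine, a carboxylic acid or a longer carbon chain, would shift the value beyond the scatter. The compounds shown also do not separate the two parts of this exchange, the loss of the benzyl carbon and the swap of fluorine for tert-butyl, as a 4-fluorophenyl group would.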